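A thiazolyl swap on the sulfonyl sulfur

The compounds below may be only part of what the source reports. "The series", "measured", "known", "first", "only" and "open" are said of these compounds alone.

In an ADME assay on HCT-116 cells (Homo sapiens) for cytotoxicity, read by CellTiter-Glo, with a stated time of 72 h (a higher number here means a weaker inhibitor, a lower number a stronger inhibitor), three compounds have been tested so far: compound 1 `Cc1cccc(S(=O)(=O)N2CCC(N3CCC(C)CC3)CC2)c1`, compound 2 `COc1cccc(S(=O)(=O)N2CCC(N3CCC(C)CC3)CC2)c1` and compound 3 `CC1CCN(C2CCN(S(=O)(=O)c3ccc(Br)c(Cl)c3)CC2)CC1`. Compound 1 gives > 5000 nM, which is a limit. Compound 2 gives > 5000 nM, also a limit. Compound 3 gives > 5000 nM, again a limit. Compound 4 `Cc1nc(Cl)sc1S(=O)(=O)N1CCC(N2CCC(C)CC2)CC1` carries 2-chloro-4-methyl-1,3-thiazol-5-yl in place of 4-bromo-3-chlorophenyl on a sulfonyl sulfur. Two measured changes on that sulfur bear on this one: a step that the two limits leave unreadable from compound 1 to compound 3 and a step that the two limits leave unreadable from compound 2 to compound 3. The record so far shows (the limit of > 5000 nM in this assay, at which 3 of the 3 values shown sit). No step beyond the scatter, in either direction, is therefore expected, and the estimated change is a step that the limit leaves unreadable from compound 3 to compound 4. Compound 4 is expected near 7000 nM, with an estimated range from 3000 nM to 15000 nM.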

Compound 4, half-maximal inhibitory concentration: > 10000 nM
Compound 4: only a limit was reported (the forecaster's own chance of this, stated with the estimate: 85%); middle value at least 1.4-fold (0.15 log units) away from the limit.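

In this assay, among these compounds, compound 4 and compound 1, compound 2 and compound 3 all carry only limits, so no step among them can be read. From the compounds shown here alone, whether the 2-chloro-4-methyl-1,3-thiazol-5-yl group changes cytotoxicity at all stays open.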